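Swapping a piperidine hydroxy for an ethyl ester

A few compounds are considered here, and "the series" means these few. Any claim that something is new, unique, unknown or untested is made for them only; others in the source may bear on it.

Compound 1, `COc1cc2c(Nc3ccc(C#N)cc3)ncnc2cc1OCCCN1CCC(C)CC1`, gives 7900 nM in a functional assay on SH-SY5Y cells (Homo sapiens) for antiproliferative activity, read by MTT assay, with a stated time of 72 h; on this read-out higher numbers stand for weaker inhibition and lower numbers for stronger inhibition.
Compound 2, `COc1cc2c(Nc3ccc(C#N)cc3)ncnc2cc1OCCCN1CCC(O)CC1`, gives > 100000 nM in this assay.

The value for compound 2 is only a limit of this assay, not a number. It sits at the limit of > 100000 nM in this assay, at which 1 of the 2 values shown sits. Compared with compound 1, the step of an at least 12-fold higher number from compound 1 to compound 2 (1.10 log units; beyond the scatter) shows that putting a hydroxy in place of a methyl on the saturated ring weakened the effect markedly.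

Compound 3, `CCOC(=O)C1CCN(CCCOc2cc3ncnc(Nc4ccc(C#N)cc4)c3cc2OC)CC1`, has not yet been measured. It differs from compound 2 by ethoxycarbonyl in place of hydroxy on a saturated ring carbon. Among the measured compounds shown here, only one measured step bears on this position, the one from compound 1 to compound 2, and it was large. That step removed a methyl and added a hydroxy; the new change removes that same hydroxy and adds an ethoxycarbonyl, so the single donor leaves again. Compound 3 is therefore expected to give a lower number than the limit of compound 2, a step of about an at least 4.0-fold lower number from compound 2 to compound 3 (0.60 log units; beyond the scatter), though the ester is a larger group than the methyl of compound 1 and the size of the gain is uncertain. The estimate for compound 3 is 25000 nM, with a range from 6000 nM to 100000 nM.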

Compound 3, half-maximal inhibitory concentration: 47200 nM
Compound 3: the middle estimate sits 1.9-fold (0.28 log units) below what was measured; low and high end bracket the measured number.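

At this saturated ring carbon, a group other than methyl and without a hydrogen-bond donor also gives a measurable number: the change from hydroxy to ethoxycarbonyl brings an at least 2.1-fold lower number from compound 2 to compound 3 (0.32 log units; beyond the scatter). That step is only a minimum, since the value of compound 2 is a limit of the assay and not a number: the limit of > 100000 nM in this assay, at which 1 of the 3 values shown sits.

Removing the hydroxy does not by itself recover the level of the methyl, however, with a 6.0-fold higher number from compound 1 to compound 3 (0.78 log units; beyond the scatter), so the methyl of compound 1 gives the lowest number of the three in this assay.

The ethoxycarbonyl group differs from the methyl in both its heavy atoms and its hydrogen-bond acceptors, so these compounds cannot show which of those differences goes with the weaker effect of compound 3. As far as these compounds go, how a plain ethyl group, a carboxylic acid or an amine on the same ring carbon would compare with compound 1 and compound 3 remains open.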